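Chlorine position on the chlorobenzyl group and cytotoxicity

This account rests on a few compounds, and the source may have more. Where it says the series, first, only, none or still open, it means among the compounds named here.

Series notes. Compound 1 `O=S1(=O)N=C(OCc2ccccc2)c2ccccc2N1Cc1ccccc1` was measured in a functional assay on HEL cells (Homo sapiens) (on this read-out lower numbers stand for higher toxicity in this test and higher numbers for lower toxicity in this test), and gives 200000 nM. Compound 2 `O=C1c2ccccc2N(Cc2ccc(Cl)cc2)S(=O)(=O)N1Cc1ccccc1` belongs to the same set; in this assay compound 2 gives > 5000 nM, which is a limit of the assay and not a number. That position is summed up by the limit of > 5000 nM in this assay, at which 1 of the 2 values shown sits, so for compound 2 only the side on which its value lies is known. For the measured compounds named here, no step between the measured compounds can be written from these two results; what compound 1 and compound 2 show are one measured number and one limit.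

Compound 3 `O=C1c2ccccc2N(Cc2cccc(Cl)c2)S(=O)(=O)N1Cc1ccccc1` has not yet been measured in this assay. It differs from compound 2 by 3-chlorophenyl in place of 4-chlorophenyl on a saturated chain carbon bound to a sulfonamide nitrogen in a ring. Going by the values given here, for a change of this kind no measured step is available; the expectation is a step in this assay of no size beyond the scatter, in either direction, so the estimated step that the limit leaves unreadable from compound 2 to compound 3 is kept small. For compound 3 the expected value in this assay is 10000 nM, with a range from 4000 nM to 100000 nM, and it is expected that the assay again reports only a limit.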

Compound 3, minimum cytotoxic concentration: > 5000 nM
Compound 3: only a limit was reported; the forecaster's own chance of this, stated with the estimate: 70%; the middle value is on the limit's open side.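

Compound 2 and compound 3 each give a limit and not a number in this assay, so no step can be read between them: the limit of > 5000 nM in this assay, at which 2 of the 3 values shown sit.

Where the true values of compound 2 and compound 3 lie, and whether 3-chlorophenyl in place of 4-chlorophenyl changes the result in this assay at all, stays open.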